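The source may hold more compounds than are shown below. What is called first, only, known or untested is meant among the compounds shown, and "the series" means these compounds.

Measured so far in an assay for inhibition of Fatty-acid amide hydrolase 1 (Rattus norvegicus); a higher number here means a weaker inhibitor, a lower number a stronger inhibitor:
compound 1 `COC(=O)c1cnc(C(=O)CCc2ccc(COc3ccccc3)cc2)o1` gives 1.6 nM
compound 2 `N#Cc1cccc(-c2cnc(C(=O)CCc3ccc(COc4ccccc4)cc3)o2)n1` gives 0.56 nM

Going by the values given here, compound 1 holds the higher of the two numbers in this assay; the only neighbour is compound 2, which lies a 2.9-fold lower number from compound 1 to compound 2 (0.46 log units; beyond the scatter). That one measured step changes the group on the core of compound 1 (6-cyanopyridin-2-yl in place of methoxycarbonyl on an aromatic carbon) and leaves the chain on the other side untouched.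

Compound 3 `COC(=O)c1cnc(C(=O)CCc2ccc(Oc3ccccc3)cc2)o1` is not yet measured. It differs from compound 1 at the far end of that chain: phenoxy in place of phenoxymethyl on an aromatic carbon. Among the compounds with values here, no measured pair varies this part of the molecule, so the step from compound 1 to compound 2 gives no guidance on size or direction here; it only shows that the series as a whole sits at very low inhibition constants. With nothing to anchor the change, the expectation for compound 3 in this assay is a small step, most likely a somewhat higher number than compound 1, written as a 2.5-fold higher number from compound 1 to compound 3 (0.40 log units; beyond the scatter). The estimated value for compound 3 is therefore 4 nM, with a range from 0.8 nM to 20 nM.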

Compound 3, inhibition constant: 1.7 nM
Beside the measured number, compound 3's estimate is 2.4-fold (0.37 log units) above it; low and high end bracket the measured number.
By their numbers in this assay, from the lowest: compound 2; then compounds 1 and 3 (each within the scatter of the next).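

In this assay, the step to phenoxy in place of phenoxymethyl, on an aromatic carbon para to a large group, is a 1.1-fold higher number from compound 1 to compound 3 (0.03 log units; within the scatter) and so lies within the usual scatter. Going by these compounds alone, this is the first measured change at the far end of the chain, and it shows that going from phenoxymethyl with 8 heavy atoms to phenoxy with 7 heavy atoms, with methoxycarbonyl held in place on the core, leaves the inhibition constant indistinguishable from that of compound 1, whereas the change on the core, a 2.9-fold lower number from compound 1 to compound 2 (0.46 log units; beyond the scatter), lies beyond the scatter. Nothing available bears on the reason for this flat result.

The compounds shown do not tell whether the same swap would also leave the number unmoved with 6-cyanopyridin-2-yl on the core, since compound 2 is the only compound carrying that group and it keeps phenoxymethyl. They also leave open how far this end of the chain can be altered, for instance with a longer chain such as phenoxyethyl, or with an amine or a carboxylic acid on the far phenyl ring.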